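Allyl capping of a hydroxy group on compound 3's core

This account rests on a few compounds, and the source may have more. Where it says the series, first, only, none or still open, it means among the compounds named here.

Measured compounds:
- compound 1, `O=C(c1cccnc1)c1cc(F)ccc1O`: 11800 nM
- compound 2, `O=C(c1cccnc1)c1ccccc1O`: 33400 nM
- compound 3, `O=C(c1cccnc1)c1cc(Cl)ccc1O`: 24800 nM

In a functional assay on PC-3 cells (Homo sapiens) for cytotoxicity, read by sulforhodamine B assay, with a stated time of 48 h (a higher number here means a weaker inhibitor, a lower number a stronger inhibitor), compound 3 gives the second highest of the three numbers. Its nearest neighbour is compound 2, and the pair sit within the scatter of each other (a 1.3-fold lower number from compound 2 to compound 3 (0.13 log units; within the scatter)). The furthest is compound 1; the step of a 2.1-fold higher number from compound 1 to compound 3 (0.32 log units; beyond the scatter) lies beyond the scatter, as does a 2.8-fold higher number from compound 1 to compound 2 (0.45 log units; beyond the scatter).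

Compound 4, `C=CCOc1ccc(Cl)cc1C(=O)c1cccnc1`, differs from compound 3 by allyl in place of hydrogen on an oxygen on an aromatic ring. Every measured step in this set concerns a halogen or hydrogen on an aromatic carbon; none touches the oxygen, so the recorded steps give no direct guide to this change. All three known steps are modest at most, and the numbers cluster in a narrow band.

With nothing shown to bear on a hydroxy to allyloxy change, compound 4 is expected to land near compound 3, with the step of a 1.1-fold lower number from compound 3 to compound 4 (0.05 log units; within the scatter) not expected to exceed the scatter by much. The estimate for compound 4 in this assay is 22000 nM, between 6000 nM and 80000 nM.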

Compound 4, half-maximal inhibitory concentration: > 100000 nM
Compound 4: only a limit was reported (the forecaster's own chance of this, stated with the estimate: 20%); middle value at least 4.5-fold (0.65 log units) away from the limit.
By their numbers in this assay, from the lowest: compound 1; then compounds 3 and 2 (each within the scatter of the next). At a limit, above all of these: compound 4.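

Going by these compounds alone, the oxygen on the aromatic ring, untouched by the earlier steps on aromatic carbon, proves to be a position where a change registers in this assay: allyl in place of hydrogen gives an at least 4.0-fold higher number from compound 3 to compound 4 (0.60 log units; beyond the scatter), and the change goes towards a weaker inhibitor. Compound 4 is recorded only as a limit, > 100000 nM, and not as a number. The step therefore sets only a minimum size, and how far the true value lies past it stays unknown: the limit of > 100000 nM in this assay, at which 1 of the 4 values shown sits.

The compounds shown do not separate the loss of the free hydroxy group from the presence of the allyl group, which a methyl ether or a longer saturated chain on the same oxygen would address. They also leave open whether an allyl group on the oxygen of compound 1 or compound 2 would produce a similar step.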